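The source may report more compounds than this note shows. Statements on the series, on what has been measured and on what is new or still open speak of the compounds shown alone.

Measured compounds in a functional assay on ZR-75-1 cells (Homo sapiens) for cytotoxicity, read by sulforhodamine B assay, with a stated time of 72 h; on this read-out lower numbers stand for an effect already at smaller amounts and higher numbers for an effect only at larger amounts of compound:
compound 1, `CCCC[C@H](OC(C)=O)[C@@H](O)[C@H](O)[C@@H]1OC(=O)C=C[C@@H]1OC(C)=O`: 6.2 ug/mL
compound 2, `CCCC[C@@H](/C=C\[C@@H]1OC(=O)C=C[C@@H]1O)OC(C)=O`: 1.9 ug/mL
compound 3, `CCCC[C@@H](/C=C\[C@@H]1OC(=O)C[C@@H](OC)[C@@H]1O)OC(C)=O`: > 20 ug/mL, a limit of the assay and not a number the limit of > 20 ug/mL in this assay, at which 1 of the 3 values shown sits.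

Compound 2 stands at the lowest of the two numbers in this assay; compound 1 gives 6.2 ug/mL, a higher number, and the gap between them lies beyond the scatter. Of compound 3 only the limit is known, so its place relative to the others cannot be told.

Compound 4, `CCCC[C@@H](/C=C\[C@@H]1OC(=O)C=C[C@@H]1OC(C)=O)OC(C)=O`, has not been measured. It differs from compound 2 by acetyl in place of hydrogen on an oxygen on a saturated carbon. Among the measured compounds shown here, no step between two measured compounds reproduces this change, so the expectation for this assay rests on compound 2 alone. The change is small and keeps the core of compound 2; no step beyond the scatter is expected in either direction, though a slight move to a higher number is held possible.

Compound 4 is expected to give about 2.5 ug/mL, within 1 ug/mL to 8 ug/mL. This estimate means a step of a 1.3-fold higher number from compound 2 to compound 4 (0.12 log units; within the scatter) that stays within the scatter.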

Compound 4, concentration for half-maximal effect: 3.6 ug/mL
The estimate for compound 4 lay 1.4-fold (0.16 log units) below the measured number, within the range that was stated.
By their numbers in this assay, from the lowest: compounds 2, 4 and 1 (each within the scatter of the next, the first and the last beyond it). At a limit, above all of these: compound 3.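

In this assay, among the compounds shown here, the change from hydroxy to acetoxy, on an oxygen on a saturated carbon, reads as a 1.9-fold higher number from compound 2 to compound 4 (0.28 log units; within the scatter), and this is the only measured step at this position. The free hydroxy of compound 2 is therefore not required to keep the number in this range, since acetyl can take the place of its hydrogen without a step beyond the scatter. No measured property shown here bears on why this step stays so small.

As far as these compounds go, only hydroxy and acetoxy are compared at this position, so it remains open whether a longer acyl chain such as hexanoyl, a benzoyl ester, a methyl ether or an amine would also stay within the scatter of compound 2. From the compounds shown here alone, it is also open whether the step would stay this small on a cell line other than this one.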